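Compound 3 and a swap on the carbonyl carbon

The compounds below may be only part of what the source reports. "The series", "measured", "known", "first", "only" and "open" are said of these compounds alone.

Measured compounds:
- compound 1 `COc1cc2ncnc(-n3nc(-c4ccccn4)nc3N)c2cc1OCCCNC(=O)OC(C)(C)C`: 2000 nM
- compound 2 `CCCCCCOC(=O)NCCCOc1cc2c(-n3nc(-c4ccccn4)nc3N)ncnc2cc1OC`: 1000 nM

Both numbers come from a physicochemical assay for solubility, in phosphate buffer, with a stated time of 18 h, at pH 7.4; a lower number here means a less soluble compound, a higher number a more soluble compound. Among the compounds with values here, compound 2, at 1000 nM, lies within the scatter of compound 1, the only other compound measured, so the two numbers set no order between them.

The next compound is compound 3 `COc1cc2ncnc(-n3nc(-c4ccccn4)nc3N)c2cc1OCCCNC(=O)C(F)(F)F`, which has not yet been measured in this assay. It differs from compound 2 as follows: trifluoromethyl in place of hexyloxy on a carbonyl carbon. In short, trifluoromethyl stands in place of hexyloxy on a carbonyl carbon.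

Within the data shown here, only one measured step bears on this change: a 2.0-fold lower number from compound 1 to compound 2 (0.30 log units; within the scatter). Among the measured compounds shown here, that step, hexyl in place of tert-butyl, stays within the scatter, but it is only a loose guide, since no measured compound carries trifluoromethyl. The data therefore point to no firm direction, and no shift beyond the scatter is expected. The expected step is a 2.0-fold higher number from compound 2 to compound 3 (0.30 log units; within the scatter). Compound 3 is estimated at 2000 nM, with an expected range of 500 nM to 8000 nM.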

Compound 3, solubility: 1000 nM
Beside the measured number, compound 3's estimate is 2.0-fold (0.30 log units) above it, within the range that was stated.
By their numbers in this assay, from the lowest: compounds 2, 3 and 1 (each within the scatter of the next).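

In this assay, trifluoromethyl in place of hexyloxy on a carbonyl carbon gives no change at the digits printed from compound 2 to compound 3 (within the scatter), and trifluoromethyl in place of tert-butoxy gives a 2.0-fold lower number from compound 1 to compound 3 (0.30 log units; within the scatter). The earlier compounds shown here carried only tert-butoxy and hexyloxy on this carbonyl carbon, both attached through oxygen, whereas compound 3 carries a group with no oxygen and so extends the comparison to a different kind of substituent, with all three compounds still lying within the scatter of one another. No measurement is available to explain why the three numbers stay so close together.

On these data alone, whether an amine, a carboxylic acid or a phenyl group on this carbonyl carbon would take the number beyond the scatter remains open, as does the effect of a chain longer than hexyl. As far as these compounds go, all three compounds also share the same core and the same chain up to the amide-type nitrogen, so it is equally open whether this lack of separation would hold if either of those parts were changed.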